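Swapping the benzyl halide on the sulfur of compound 2

The source may hold more compounds than are shown below. What is called first, only, known or untested is meant among the compounds shown, and "the series" means these compounds.

In a functional assay on the whole organism (artery, strain albino) with Rattus norvegicus as the target, with a stated time of 300 min, at a dose of 10 mg/kg by the oral route (on this read-out higher numbers stand for more inhibition at the one dose given (going by the name of the read-out) and lower numbers for less inhibition), two compounds from this series have been measured. Compound 1, `CC1=C(C(=O)Nc2ccc(Br)cc2)C(c2ccc(Cl)cc2Cl)N=C(SCc2ccc(F)cc2)N1`, gives 38.5%. Compound 2, `COc1ccc(C2N=C(SCc3ccccc3Cl)NC(C)=C2C(=O)Nc2ccc(Br)cc2)cc1`, gives 17.9%, which is the lower of the two numbers, and its distance from compound 1 is larger than the usual scatter of repeated measurements. Among the compounds with values here, compound 1 and compound 2 differ in more than one place, so no single step between them is defined.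

Compound 3, `COc1ccc(C2N=C(SCc3ccc(F)cc3)NC(C)=C2C(=O)Nc2ccc(Br)cc2)cc1`, has not yet been measured. It differs from compound 2 in one place: 4-fluorophenyl in place of 2-chlorophenyl on a saturated chain carbon bound to a sulfur. The group that enters is the same benzyl group that compound 1 carries on its sulfur, while the rest of compound 3 matches compound 2.

Within the data shown here, since only two numbers exist and the two measured compounds differ in two places, the size of this step cannot be read from the data. He expects a step from compound 2 to compound 3 of a number 7.1 percentage points higher from compound 2 to compound 3 (within the scatter), upward but not clearly beyond the scatter. For compound 3 the estimated value in this assay is 25%, with a range from 10% to 42%.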

Compound 3, a percentage reported as inhibition, in the whole organism at one dose (the size of the read-out at that dose, not a potency): 26.2%
Compound 3: middle estimate off by 1.2 percentage points, on the low side, within the range that was stated.
By their numbers in this assay, from the lowest: compounds 2 and 3 (each within the scatter of the next); then compound 1.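

In this assay the replacement on a saturated chain carbon bound to a sulfur amounts to a number 8.3 percentage points higher from compound 2 to compound 3 (within the scatter) and so does not separate the two compounds: at this place, 2-chlorobenzyl and 4-fluorobenzyl cannot be told apart on this read-out. Within the data shown here, compound 3 also provides the first comparison in one place on the other side of the molecule, where 4-methoxyphenyl in place of 2,4-dichlorophenyl on a saturated ring carbon gives a number 12.3 percentage points lower from compound 1 to compound 3 (beyond the scatter) and this step, though modest, is the only one of the two that clears the scatter. Nothing available accounts for either step.

The compounds shown carry only halogen-bearing benzyl groups on the sulfur, so it remains open whether this place would accept a very different group, such as a simple ethyl chain, a benzyl group bearing a carboxylic acid, or a chain ending in an amine. On these data alone, at the saturated ring carbon, it is equally open whether 4-chlorophenyl or unsubstituted phenyl would stand with compound 1 or with compound 3, so the step there cannot yet be assigned to the chlorines or to the methoxy group.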